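Swapping a ring substituent on an aryl thiazolidinone amide

The source may hold more compounds than are shown below. What is called first, only, known or untested is meant among the compounds shown, and "the series" means these compounds.

Measured so far in a functional assay on 143B cells (Homo sapiens) for inhibition, read by CCK-8 assay, with a stated time of 72 h, tested at 1 uM; a higher number here means more inhibition at the concentration tested (going by the name of the read-out), a lower number less inhibition:
compound 1 `COc1ccc(C)cc1N1C(=O)CSC1c1cccc(C(=O)NCCCCc2ccccc2)c1`: 29%
compound 2 `COc1ccc(OC)c(N2C(=O)CSC2c2cccc(C(=O)NCCCCc3ccccc3)c2)c1`: 2%
compound 3 `CCN1C(=O)CSC1c1cccc(C(=O)NCCCCc2ccccc2)c1`: 40%

Compound 1 stands second highest of the three numbers. Its nearest neighbour is compound 3, where a number 11 percentage points higher from compound 1 to compound 3 (beyond the scatter); furthest is compound 2, where a number 27 percentage points lower from compound 1 to compound 2 (beyond the scatter). Between compound 2 and compound 3 the gap is a number 38 percentage points higher from compound 2 to compound 3 (beyond the scatter).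

Compound 4 `COc1cc(F)ccc1N1C(=O)CSC1c1cccc(C(=O)NCCCCc2ccccc2)c1` is not yet measured. The change from compound 1 is 4-fluoro-2-methoxyphenyl in place of 2-methoxy-5-methylphenyl on an amide-type nitrogen in a ring.

Among the measured compounds shown here, the only measured step that keeps an aryl group on that nitrogen and alters its substituent is a number 27 percentage points lower from compound 1 to compound 2 (beyond the scatter), a modest drop when methoxy replaced methyl. The steps to compound 3 replace the whole aryl group with ethyl and bear less directly. Changing one substituent on this aryl ring has thus moved the readout, so a step is plausible, but its direction is not settled by the data. Compound 4 is expected near compound 1, with a step of a number 5 percentage points lower from compound 1 to compound 4 (within the scatter), at an estimated 24%, within 4% to 44%.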

Compound 4, a percentage reported as inhibition, at one concentration (the size of the read-out at that concentration, not a potency): 63%
Estimate against measurement, compound 4: 39 percentage points below; the whole stated range lies below it.
By their numbers in this assay, from the lowest: compound 2; then compound 1; then compound 3; then compound 4.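

In this assay, an aryl group on this amide-type nitrogen can outdo ethyl, with a number 23 percentage points higher from compound 3 to compound 4 (beyond the scatter), so the aryl ring is not a liability in itself, as compound 1 and compound 2 alone might have suggested. With the methoxy group kept, changing only the other ring substituent gives a number 34 percentage points higher from compound 1 to compound 4 (beyond the scatter), and the comparison with the dimethoxy ring gives a number 61 percentage points higher from compound 2 to compound 4 (beyond the scatter), so this one substituent can separate near-absent inhibition from the highest number in the set. Nothing shown gives a reason for these differences.

The names 4-fluoro-2-methoxyphenyl and 2-methoxy-5-methylphenyl differ in both the group and its ring number, so the effect of the fluorine atom cannot be separated from that of its location. From the compounds shown here alone, how chlorine, a nitrile or an amine on this ring would read out also remains open.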